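The source may hold more compounds than are shown below. What is called first, only, known or untested is meant among the compounds shown, and "the series" means these compounds.

Compound 1 `CCc1nnc(SCc2ccccc2)n1N1C(=O)c2ccccc2C1=O` and compound 2 `C#CCSc1nnc(-c2cc(OC)c(OC)c(OC)c2)n1N1C(=O)c2ccccc2C1=O` have both been tested in a functional assay on HepG2 cells (Homo sapiens) for cytotoxicity, read by MTT assay, with a stated time of 48 h; on this read-out higher numbers stand for weaker inhibition and lower numbers for stronger inhibition. In this assay compound 1 gives > 200000 nM, which is a limit of the assay rather than a measured number. In this assay compound 2 likewise gives > 200000 nM, again a limit and not a number. Both values sit at the limit of > 200000 nM in this assay, at which 2 of the 2 values shown sit, so compound 2 stands level with compound 1 as far as the shown numbers go, and no step between measured compounds can be read from them. Compound 3 `COc1cc(-c2nnc(SCC(=O)c3ccccc3)n2N2C(=O)c3ccccc3C2=O)cc(OC)c1OC` has not yet been measured. It differs from compound 2 by benzoyl in place of ethynyl on a saturated chain carbon bound to a sulfur. With compound 2 at a limit, only the departure from that limit can be guessed. The replacement is expected to bring no shift beyond the scatter, and the step expected is a number no higher from compound 2 to compound 3 (the limit leaves the size open). Compound 3 is thus expected to give 200000 nM in this assay, with a range from 50000 nM to 800000 nM, and most likely to be reported only as a limit once more.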

Compound 3, half-maximal inhibitory concentration: 171000 nM
Compound 3: middle estimate off by 1.2-fold (0.07 log units), on the high side, within the range that was stated.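

In this assay, among these compounds, compound 3 gives 171000 nM, the first value in this set that is a number rather than a limit, so this place on the saturated chain carbon bound to a sulfur now has one measured point. Benzoyl in place of ethynyl there, a change that brings in a six-membered aromatic ring and a hydrogen-bond acceptor, amounts to an at least 1.1-fold lower number from compound 2 to compound 3 (0.06 log units; that floor lies within the scatter), and with a limit at one end of that step its full size stays open. Compound 1 and compound 2 remain at a limit of the assay and not at a number: the limit of > 200000 nM in this assay, at which 2 of the 3 values shown sit.

The aromatic ring and the carbonyl of benzoyl enter together in this one change, so the compounds shown do not tell which of the two goes with the value of compound 3. Going by these compounds, it also remains open how a carboxylic acid, an amine or a longer chain on the same sulfur would read on the core of compound 3 in this assay, and whether any such group would give a number clearly beyond the scatter.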